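Swapping the Ester Side Chain: What to Expect of Compound 4

This account rests on a few compounds, and the source may have more. Where it says the series, first, only, none or still open, it means among the compounds named here.

Three compounds have so far been measured in a functional assay on HeLa cells (Homo sapiens) for cytotoxicity, read by MTT assay; a higher number here means a weaker inhibitor, a lower number a stronger inhibitor:

compound 1 `CCCCC(O)CC(=O)O[C@H](CC=C(C)C)C1=CC(=O)c2c(O)ccc(O)c2C1=O` gives 72200 nM
compound 2 `CCCC(CC(=O)O[C@H](CC=C(C)C)C1=CC(=O)c2c(O)ccc(O)c2C1=O)OC(C)=O` gives 51200 nM
compound 3 `CC(=O)OC(C)CO[C@H](CC=C(C)C)C1=CC(=O)c2c(O)ccc(O)c2C1=O` gives 40100 nM

Among these three, compound 2 holds the second highest number; its neighbours on either side, compound 3 and compound 1, both lie within the scatter of it, so the three compounds cannot be told apart on these numbers. The piece now turns to compound 4 `CC(C)=CC[C@@H](OC(=O)CC(C)(O)c1ccccc1)C1=CC(=O)c2c(O)ccc(O)c2C1=O`, which differs from compound 2 in one place: 1-hydroxy-1-phenylethyl in place of 1-acetoxybutyl on a saturated chain carbon bound to a carbonyl carbon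

Among the measured compounds shown here, two measured steps bear on this. The step of a 1.4-fold lower number from compound 1 to compound 2 (0.15 log units; within the scatter) alters the same saturated chain carbon bound to a carbonyl carbon and stays within the scatter. The step of a 1.8-fold lower number from compound 1 to compound 3 (0.26 log units; within the scatter) replaces the whole ester arm and likewise stays within the scatter. Neither change at this position has moved the number beyond the scatter, so no step beyond it is expected here either: the estimate for compound 4 means a step of a 1.0-fold lower number from compound 2 to compound 4 (0.01 log units; within the scatter). Compound 4 is therefore expected to give about 50000 nM, with a range from 20000 nM to 120000 nM.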

Compound 4, half-maximal inhibitory concentration: 85700 nM
Compound 4: the middle estimate sits 1.7-fold (0.23 log units) below what was measured; measured number inside the range.
By their numbers in this assay, from the lowest: compounds 3, 2, 1 and 4 (each within the scatter of the next, the first and the last beyond it).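

In this assay the exchange of 1-acetoxybutyl for 1-hydroxy-1-phenylethyl gives a 1.7-fold higher number from compound 2 to compound 4 (0.22 log units; within the scatter) and the exchange of 1-hydroxypentyl for the same group gives a 1.2-fold higher number from compound 1 to compound 4 (0.07 log units; within the scatter) on the same saturated chain carbon bound to a carbonyl carbon. The earlier compounds shown here carried only open-chain groups here, whereas this change brings in a six-membered aromatic ring of carbon only, and neither step goes beyond the scatter. No available evidence accounts for this result.

The compounds shown leave open whether a group of another kind at this place, such as an amine or a carboxylic acid, would take the number beyond the scatter. They also leave open whether a longer chain carrying the phenyl ring would do so.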